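A few compounds are considered here, and "the series" means these few. Any claim that something is new, unique, unknown or untested is made for them only; others in the source may bear on it.

Measured in a functional assay on HeLa cells (Homo sapiens) for antiproliferative activity, read by MTT assay, with a stated time of 72 h; on this read-out lower numbers stand for stronger inhibition and higher numbers for weaker inhibition:

- compound 1 `C/C=C/C(=O)Nc1cccc(Oc2nc(Nc3ccn(C)n3)nc3c2CSCC3)c1`: > 50000 nM
- compound 2 `C/C=C/C(=O)Nc1cccc(Oc2nc(Nc3ccc(OC)cc3)nc3c2CSCC3)c1`: > 50000 nM
- compound 3 `C=CC(=O)Nc1cccc(Oc2nc(Nc3ccc(OC)nc3)nc3c2CSCC3)c1`: 26300 nM

Compound 1 stands at > 50000 nM, which is a limit of this assay and not a number. Compound 2 likewise stands at a limit, > 50000 nM. Among the compounds with values here, compound 3, at 26300 nM, has the only true number of the three.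

Compound 4 `C/C=C/C(=O)Nc1cccc(Oc2nc(Nc3ccc(OC)nc3)nc3c2CSCC3)c1` differs from compound 3 in one place: prop-1-en-1-yl in place of vinyl on a carbonyl carbon.

Within the data shown here, no measured step covers this change. Among the measured compounds shown here, the one measured step is a step that the two limits leave unreadable from compound 1 to compound 2, which concerns another part of the molecule and offers no size to carry over. The nearest guide is the limit of > 50000 nM in this assay, at which 2 of the 3 values shown sit: compound 1 and compound 2 both carry the prop-1-en-1-yl group of compound 4, though each also differs from it elsewhere. A modest shift towards weaker inhibition is therefore expected, and the assay may report only a limit. The estimated change is a 1.7-fold higher number from compound 3 to compound 4 (0.23 log units; within the scatter). For compound 4 the estimated value is 45000 nM, with an expected range from 18000 nM to 100000 nM.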

Compound 4, half-maximal inhibitory concentration: 16500 nM
Beside the measured number, compound 4's estimate is 2.7-fold (0.44 log units) above it; measured number outside the range, below it.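

In this assay, within the data shown here, the change from vinyl to prop-1-en-1-yl on a carbonyl carbon gives a 1.6-fold lower number from compound 3 to compound 4 (0.20 log units; within the scatter), so this swap, read directly for the first time, makes no difference that can be told from the usual scatter. With prop-1-en-1-yl held in place, the group on the nitrogen now has a readable effect: 6-methoxypyridin-3-yl in place of 4-methoxyphenyl gives an at least 3.0-fold lower number from compound 2 to compound 4 (0.48 log units; beyond the scatter), and 6-methoxypyridin-3-yl in place of 1-methyl-1H-pyrazol-3-yl gives an at least 3.0-fold lower number from compound 1 to compound 4 (0.48 log units; beyond the scatter). Both steps start from a limit, so their full size remains unknown: the limit of > 50000 nM in this assay, at which 2 of the 4 values shown sit.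

Still open, going by these compounds, is whether a longer chain, or a chain ending in an amine, on the carbonyl carbon would shift the number. Also open, on these data alone, is whether an amine in place of the methoxy group of 6-methoxypyridin-3-yl would do so.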